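Adding Fluorine to the Hydroxyphenyl of Compound 2

The compounds below may be only part of what the source reports. "The series", "measured", "known", "first", "only" and "open" are said of these compounds alone.

Of the compounds shown here, two have been measured in an assay on isolated protein for inhibition of 17-beta-hydroxysteroid dehydrogenase type 1 (Homo sapiens), with a stated time of 10 min; on this read-out lower numbers stand for stronger inhibition and higher numbers for weaker inhibition. Compound 1 `O=C(c1ccc(-c2ccc(O)c(F)c2)cc1)c1cccc(O)c1` gives 2430 nM, and compound 2 `O=C(c1ccc(-c2ccc(O)c(Cl)c2)cc1)c1cccc(O)c1` gives 571 nM. Going by the values given here, the one step between them, a 4.3-fold lower number from compound 1 to compound 2 (0.63 log units; beyond the scatter), concerns the ring that carries the phenol and a halogen. Among the compounds with values here, on the two numbers so far, compound 2 stands lowest, with compound 1 the only neighbour, a step beyond the scatter away.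

Compound 3 `O=C(c1ccc(-c2ccc(O)c(Cl)c2)cc1)c1ccc(F)c(O)c1` differs from compound 2 in one place: fluoro in place of hydrogen on an aromatic carbon. The fluorine enters on the other ring, the one attached to the carbonyl, ortho to its hydroxy group and para to a large group; read a bond further out, a 3-hydroxyphenyl becomes a 4-fluoro-3-hydroxyphenyl.

Within the data shown here, no measured step bears directly on this change. The step from compound 1 to compound 2 exchanges one halogen for another on a different ring and says nothing about placing a fluorine next to a phenol on this one. The expectation for compound 3 is therefore a step within the scatter, a 1.1-fold lower number from compound 2 to compound 3 (0.06 log units; within the scatter) in this assay, with no direction favoured. The estimate for compound 3 in this assay is 500 nM, between 150 nM and 1600 nM.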

Compound 3, half-maximal inhibitory concentration: 53 nM
Beside the measured number, compound 3's estimate is 9.4-fold (0.97 log units) above it; the whole stated range lies above it.
By their numbers in this assay, from the lowest: compound 3; then compound 2; then compound 1.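

In this assay the change from 3-hydroxyphenyl to 4-fluoro-3-hydroxyphenyl gives an 11-fold lower number from compound 2 to compound 3 (1.03 log units; beyond the scatter) and makes compound 3 the lowest of the series, with steps beyond the scatter to both other compounds. This shows that a single fluoro in place of hydrogen, ortho to a hydroxy group and para to a large group, can shift this read-out substantially, and that the ring attached to the carbonyl also bears on inhibition. The earlier step, a 4.3-fold lower number from compound 1 to compound 2 (0.63 log units; beyond the scatter), concerned only the exchange of one halogen for another on the other ring and gave no information about this position, while nothing measured here accounts for the size of the new step.

The compounds shown leave open whether this gain is specific to fluoro or would also appear with a methyl, a methoxy or an amine on the same aromatic carbon. They also leave open whether the same fluoro would give a step of similar size on the core of compound 1, which carries fluoro rather than chloro on its other ring.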